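Chloro in Place of Methyl: From Compound 2 to Compound 3

The source may hold more compounds than are shown below. What is called first, only, known or untested is meant among the compounds shown, and "the series" means these compounds.

Compound 2 `Cc1ccc(/C=C/C(=O)NCCNc2ccnc3cc(Cl)ccc23)cc1` was tested in an ADME assay on Vero cells (Chlorocebus sabaeus) for cytotoxicity, read by MTT assay, with a stated time of 72 h (a lower number here means that less compound is tolerated, a higher number that more compound is tolerated), and gave 4000 nM, the lowest of the two numbers recorded, though the gap to compound 1 lies within the scatter. Compound 1 `O=C(COc1ccccc1C(=O)/C=C/c1ccc(Cl)cc1)NCCNc1ccnc2cc(Cl)ccc12` gave 4980 nM in this assay. Compound 3 `O=C(/C=C/c1ccc(Cl)cc1)NCCNc1ccnc2cc(Cl)ccc12` differs from compound 2 by chloro in place of methyl on an aromatic carbon. Going by the values given here, no step between measured compounds is available for this change, so no shift beyond the scatter is expected: the step of no change at the digits printed from compound 2 to compound 3 (within the scatter) is estimated to be small. Compound 3 is accordingly expected to give 4000 nM, with a range from 2000 nM to 8000 nM.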

Compound 3, half-maximal cytotoxic concentration: 6930 nM
Estimate against measurement, compound 3: 1.7-fold (0.24 log units) below; the measured number falls inside the stated range.
By their numbers in this assay, from the lowest: compounds 2, 1 and 3 (each within the scatter of the next).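

In this assay, going by these compounds alone, the exchange of 4-methylphenyl for 4-chlorophenyl gives a 1.7-fold higher number from compound 2 to compound 3 (0.24 log units; within the scatter) and this is the first step available between compounds that differ in one place. On this six-membered aromatic ring, methyl and chloro therefore cannot be told apart by this read-out. Nothing at hand offers an explanation of this result.

On these data alone, whether methoxy, an amine or a carboxylic acid in the same place would move the number beyond the scatter stays open. So does the outcome with hydrogen there.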